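The source may hold more compounds than are shown below. What is called first, only, known or untested is meant among the compounds shown, and "the series" means these compounds.

Measured in a functional assay (aorta) for antagonist activity, with Oryctolagus cuniculus as the target; on this read-out lower numbers stand for stronger inhibition and higher numbers for weaker inhibition:
- compound 1 `CCCSC1=NS(=O)(=O)c2ccc(C(=O)O)cc2N1Cc1ccc(-c2ccccc2-c2nn[nH]n2)cc1`: 0.08 nM
- compound 2 `CCCSC1=Nc2ccccc2S(=O)(=O)N1Cc1ccc(-c2ccccc2-c2nn[nH]n2)cc1`: 640 nM
- compound 3 `CCCSC1=NS(=O)(=O)c2ccccc2N1Cc1ccc(-c2ccccc2-c2nn[nH]n2)cc1`: 93 nM

For the measured compounds named here, of these three numbers, the one for compound 3 is the second highest, with compound 1 lower and compound 2 higher. Compound 4 `CCCSC1=NS(=O)(=O)c2ccccc2N1Cc1ccc(-c2ccccc2C(=O)O)cc1` differs from compound 3 in one place, with carboxy in place of 2H-tetrazol-5-yl on an aromatic carbon.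

Going by the values given here, no measured step makes this swap. Among the compounds with values here, the only measured step, a 1200-fold higher number from compound 1 to compound 3 (3.07 log units; beyond the scatter), removes a carboxy at another place, so it bears only indirectly: one group change moved the number a long way in that pair. The data fix no direction, so a moderate rise in this assay, smaller than that step, is only a cautious expectation. The expected step is a 5.4-fold higher number from compound 3 to compound 4 (0.73 log units; beyond the scatter). For compound 4 the estimated value is 500 nM, with an expected range of 60 nM to 4000 nM.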

Compound 4, antagonist equilibrium constant: 20 nM
Beside the measured number, compound 4's estimate is 25-fold (1.40 log units) above it; measured number below the stated range.
By their numbers in this assay, from the lowest: compound 1; then compound 4; then compound 3; then compound 2.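

Carboxy in place of 2H-tetrazol-5-yl on this aromatic carbon brings a 4.7-fold lower number from compound 3 to compound 4 (0.67 log units; beyond the scatter) in this assay. For the compounds shown here, this is the first measured change at this position, and it shows that the tetrazole ring is not needed here for activity: a group with no ring gives the lower number on this read-out. Nothing available explains that fall. Still open, on these data alone, is whether the same swap would lower the number in compound 1, which also carries a carboxy on the core. As far as these compounds go, how an amide or a methyl ester would fare at this position also remains open.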